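The source may hold more compounds than are shown below. What is called first, only, known or untested is meant among the compounds shown, and "the series" means these compounds.

Measured in a functional assay on M21 cells (Homo sapiens) for antiproliferative activity, read by sulforhodamine B assay, with a stated time of 48 h; a lower number here means a stronger inhibitor, a higher number a weaker inhibitor:
- compound 1 `Cc1cccc(NS(=O)(=O)c2ccc(N3CCNC3=O)cc2)c1`: 69 nM
- compound 2 `Cc1ccc(NS(=O)(=O)c2ccc(N3CCNC3=O)cc2)cc1`: 260 nM
- compound 3 `O=C1NCCN1c1ccc(S(=O)(=O)Nc2ccc(Br)cc2)cc1`: 130 nM

Compound 3, at 130 nM, lies within the scatter of both other compounds, with a 1.9-fold higher number from compound 1 to compound 3 (0.28 log units; within the scatter) and a 2.0-fold lower number from compound 2 to compound 3 (0.30 log units; within the scatter). Only the remaining pair is separated beyond the scatter, by a 3.8-fold higher number from compound 1 to compound 2 (0.58 log units; beyond the scatter).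

Compound 4 `Cc1ccc(C)c(NS(=O)(=O)c2ccc(N3CCNC3=O)cc2)c1`, not yet measured, carries 2,5-dimethylphenyl in place of 4-bromophenyl on a sulfonamide nitrogen. All three measured steps changed the group at this same place, and the largest, seen between compound 1 and compound 2 as a 3.8-fold higher number from compound 1 to compound 2 (0.58 log units; beyond the scatter), was only modest. Among the measured compounds shown here, no measured compound carries two methyl groups on this ring, so the new pattern remains untested, and the range must stay wide. No step beyond the scatter is expected in this assay. The estimated step is a 1.2-fold lower number from compound 3 to compound 4 (0.07 log units; within the scatter). Compound 4 is expected at about 110 nM, with an estimated range of 35 nM to 350 nM.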

Compound 4, half-maximal inhibitory concentration: 27 nM
The estimate for compound 4 lay 4.1-fold (0.61 log units) above the measured number; the measured number lies below the stated range.
By their numbers in this assay, from the lowest: compound 4; then compounds 1, 3 and 2 (each within the scatter of the next, the first and the last beyond it).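

Among the compounds shown here, earlier, only one pair of compounds stood apart beyond the scatter; now the 2,5-dimethylphenyl group on the sulfonamide nitrogen separates from all three other groups in this assay, with a 4.8-fold lower number from compound 3 to compound 4 (0.68 log units; beyond the scatter) and a 9.6-fold lower number from compound 2 to compound 4 (0.98 log units; beyond the scatter) for this one change of group. Methyl in place of hydrogen on an aromatic carbon gives a 2.6-fold lower number from compound 1 to compound 4 (0.41 log units; beyond the scatter) and so shows that a ring with two methyl groups can go with a lower number than either ring with one. Nothing available bears on why this change lowers the number.

Only one ring with two methyl groups is shown, so how far the result depends on where they sit cannot be told. From the compounds shown here alone, whether a methoxy group, an amine or a carboxylic acid on this ring would keep the number this low also remains open.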